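Ethyl Ester of an Acid Side Chain: Expected Maximal Response

This account rests on a few compounds, and the source may have more. Where it says the series, first, only, none or still open, it means among the compounds named here.

Measured compounds:
compound 1 `C=CCn1c(=O)n([C@@H]2O[C@H](CO)[C@H]3OC(C)(CCC(=O)O)O[C@H]32)c2nc(N)nc(O)c21` — 0%
compound 2 `C=CCn1c(=O)n(C2OC(CO[Si](C)(C)C(C)(C)C)[C@@H](O)[C@H]2O)c2nc(N)nc(O)c21` — 6%
compound 3 `C=CCn1c(=S)n(COCCO)c2nc(N)nc(O)c21` — 28%

In a functional assay on YAC-1 cells (Mus musculus) (a higher number here means a larger maximal response, a lower number a smaller maximal response), compound 1 gives 0%, the lowest of the three numbers shown. The nearest number is that of compound 2, which lies within the usual scatter of compound 1, so the two cannot be told apart. Compound 3 stands beyond the scatter above compound 1 and is the only one of the three that shows a response clearly different from it.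

Compound 4 `C=CCn1c(=O)n([C@@H]2O[C@H](CO)[C@H]3OC(C)(CCC(=O)OCC)O[C@H]32)c2nc(N)nc(O)c21` is not yet measured. It differs from compound 1 in one place: ethyl in place of hydrogen on an oxygen next to a carbonyl group. The acid of compound 1 thus becomes an ethyl ester, on an oxygen next to a carbonyl group, with everything else in the shared core left as it was.

Among the compounds with values here, no measured pair shows this kind of change, so its effect in this assay is unknown. Compound 2, which also keeps the core of compound 1 with a different sugar dressing, lies within the scatter of compound 1, which suggests that such changes to the sugar part need not move the maximal response far. The step from compound 1 to compound 4 is therefore expected to be small, a number 8 percentage points higher from compound 1 to compound 4 (within the scatter), and may well stay within the scatter. Compound 4 is estimated to give 8%, with a range from 0% to 25%.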

Compound 4, largest response reached (reported as maximal response), in percent of the reference or control that the assay uses: 19%
Compound 4: the middle estimate sits 11 percentage points below what was measured; low and high end bracket the measured number.
By their numbers in this assay, from the lowest: compounds 1 and 2 (each within the scatter of the next); then compounds 4 and 3 (each within the scatter of the next).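

In this assay, putting ethyl in place of hydrogen on an oxygen next to a carbonyl group, which turns carboxy into ethoxycarbonyl, gives a number 19 percentage points higher from compound 1 to compound 4 (beyond the scatter) and so moves the maximal response by more than the usual scatter. Within the data shown here, none of the earlier compounds differed from another in only one place, so this is the first sign that a single change at this end of the side chain can alter the read-out, with the rest of the shared core left as it was. No measurement here explains why the ethyl ester and the acid differ.

The compounds shown leave open whether this step depends on ethyl itself, or whether methyl, a longer chain such as butyl on the same oxygen, or an amide in place of the ester would give a similar maximal response. They also leave open how the response would change if the chain that carries the ester were shortened or lengthened, so a single step gives the direction of one change and not yet a trend.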